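Methyl on the Ring Amine: Compound 3 to Compound 4

The source may hold more compounds than are shown below. What is called first, only, known or untested is meant among the compounds shown, and "the series" means these compounds.

The compounds measured so far, with their readings:

Compound 1, `Cc1ccc2[nH]c(C(=O)N[C@H]3CN(S(=O)(=O)c4ccnnc4)C[C@@H]3C(=O)NCCN(C)C)cc2c1`, gives 2 uL/min.
Compound 2, `Cc1ccc2[nH]c(C(=O)N[C@H]3CCN(S(=O)(=O)N(C)C)C[C@@H]3C(=O)NCCN(C)C)cc2c1`, gives 10 uL/min.
Compound 3, `Cc1ccc2[nH]c(C(=O)N[C@H]3CN(S(=O)(=O)c4ccccc4)C[C@@H]3C(=O)NC[C@H]3CCCN3)cc2c1`, gives 10 uL/min.

All three were measured in an ADME assay on cells (Hepatocyte, Rattus norvegicus) for metabolic stability; a lower number here means slower removal, a higher number faster removal of the compound. Compound 3 stands level with compound 2 at the digits shown, and the two together hold the highest numbers of the three. The gap between compound 3 and compound 2 lies within the usual scatter, so no order can be read between them. Compound 1 sits furthest away, with a number lower than compound 3 by a margin that lies beyond the scatter.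

The next compound, compound 4, `Cc1ccc2[nH]c(C(=O)N[C@H]3CN(S(=O)(=O)c4ccccc4)C[C@@H]3C(=O)NC[C@H]3CCCN3C)cc2c1`, has not yet been measured in this assay. It differs from compound 3 in one place: methyl in place of hydrogen on an amine nitrogen in a ring. The change turns pyrrolidin-2-yl into 1-methylpyrrolidin-2-yl, a single carbon added on the amine nitrogen in the five-membered ring.

Among the compounds with values here, no measured pair here shows what such a change does, so the size of the step is open. The expected step from compound 3 to compound 4 is a 1.4-fold higher number from compound 3 to compound 4 (0.15 log units; within the scatter), a small rise that may well stay within the scatter. Compound 4 is therefore estimated at 14 uL/min, with a range from 6 uL/min to 35 uL/min.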

Compound 4, intrinsic clearance in a liver preparation (reported as CLH), per the amount of preparation that the assay uses: 21 uL/min
The estimate for compound 4 lay 1.5-fold (0.18 log units) below the measured number; the measured number falls inside the stated range.
By their numbers in this assay, from the lowest: compound 1; then compounds 2 and 3 (each within the scatter of the next); then compound 4.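

In this assay, within the data shown here, compound 3 and compound 4 form the only measured pair that differs in one place, and methyl in place of hydrogen on the amine nitrogen of the five-membered ring gives a 2.1-fold higher number from compound 3 to compound 4 (0.32 log units; beyond the scatter). This shows that adding a single carbon at this position, turning pyrrolidin-2-yl into 1-methylpyrrolidin-2-yl, is enough to carry the number modestly past the usual scatter, and that the direction on this one background is towards faster removal. Nothing in the available information accounts for this rise, so it stands as an observation without an established cause.

On these data alone, whether an ethyl or acetyl group on the same nitrogen would raise the number further, leave it unchanged or lower it remains open. Among these compounds, it is also open whether methyl at this position would give a step of similar size and direction in a molecule with a different sulfonyl group, such as the one in compound 1, as a single pair cannot establish a general pattern.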